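The source may report more compounds than this note shows. Statements on the series, on what has been measured and on what is new or still open speak of the compounds shown alone.

Measured compounds:
- compound 1 `C=C(CC)C(=O)c1ccc(OCC(=O)Nc2cccc(C(=O)O)c2)c(Cl)c1Cl`: 20600 nM
- compound 2 `C=C(CC)C(=O)c1ccc(OCC(=O)Nc2ccc3cc(C(=O)O)ccc3c2)c(Cl)c1Cl`: 3700 nM

In a functional assay on CLL cells (Homo sapiens) for cytotoxicity, read by MTT assay, with a stated time of 48 h (a higher number here means that more compound is needed for the effect, a lower number that less compound is needed), compound 1 gives 20600 nM, the highest of the two numbers shown. Its nearest neighbour is compound 2, which in this assay gives 3700 nM, a clearly lower number, and that gap lies beyond the usual scatter of repeated measurements. For the measured compounds named here, no single-point step between measured compounds is available here, so there is no measured change of this kind to lean on.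

The compound still to be measured is compound 3 `C=C(CC)C(=O)c1ccc(OCC(=O)NO)c(Cl)c1Cl`. It shares the core of compound 1 and differs from it in one place: hydroxy in place of 3-carboxyphenyl on an amide-type nitrogen. Only compound 1 and compound 2 offer any guidance, and neither of them carries a change of this sort, so the direction of the step remains uncertain. The expectation is a modest rise in the number, small enough that it may not clear the scatter. For compound 3 the estimated value in this assay is 30000 nM, with a range from 8000 nM to 110000 nM. That estimate means an expected step of a 1.5-fold higher number from compound 1 to compound 3 (0.16 log units; within the scatter).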

Compound 3, half-maximal effective concentration: 4500 nM
The estimate for compound 3 lay 6.7-fold (0.82 log units) above the measured number, and the stated range ends above it.
By their numbers in this assay, from the lowest: compounds 2 and 3 (each within the scatter of the next); then compound 1.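

On the amide-type nitrogen, putting hydroxy in place of 3-carboxyphenyl gives, in this assay, a 4.6-fold lower number from compound 1 to compound 3 (0.66 log units; beyond the scatter). So at this position the cells respond to less compound even though the six-membered aromatic ring and its carboxylic acid are gone, and the much smaller hydroxy, with no ring at all, serves better than the group it replaces. Nothing measured here explains this gain, and the shift in this assay alone cannot say which part of the change produces it.

For the compounds shown here, the single swap changes two things at once, removing 3-carboxyphenyl and adding hydroxy, so it remains open whether the lower number comes from the loss of the ring or from the hydroxy itself. A methoxy group, a plain amide hydrogen or a small alkyl chain such as methyl on the same nitrogen would help separate these two readings, and a short chain ending in a carboxylic acid would show whether the acid can stay once the ring is gone.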